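Working notes on compounds 1 to 3 in EKVX growth inhibition

The source may hold more compounds than are shown below. What is called first, only, known or untested is meant among the compounds shown, and "the series" means these compounds.

Measured so far:
compound 1 `N#C/C(=C\c1c(-c2ccccc2)[nH]c2ccccc12)C(=O)c1ccccc1`: 10000 nM
compound 2 `COc1ccc2[nH]c(-c3ccccc3)c(C=C(C#N)C#N)c2c1`: 4100 nM

In a functional assay on EKVX cells (Homo sapiens) for inhibition, read by sulforhodamine B assay, with a stated time of 48 h (a lower number here means a stronger inhibitor of growth, a higher number a weaker inhibitor of growth), compound 1 gives 10000 nM, the highest of the two numbers here; the nearest is compound 2 at 4100 nM, a gap beyond the scatter. Compound 3 `N#C/C(=C\c1c(-c2ccccc2)[nH]c2ccccc12)S(=O)(=O)c1ccccc1` has not been measured in this assay. It differs from compound 1 in one place: phenylsulfonyl in place of benzoyl on a double-bonded chain carbon bound to a double-bonded chain carbon and a triple-bonded carbon. Among the measured compounds shown here, no measured pair shows what this exchange does, so the expected step is a 1.3-fold lower number from compound 1 to compound 3 (0.10 log units; within the scatter), none beyond the scatter. Compound 3 is therefore estimated at 8000 nM, with a range from 2500 nM to 25000 nM.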

Compound 3, concentration for 50% growth inhibition: 6200 nM
For compound 3 the middle estimate is 1.3-fold (0.11 log units) above the measured one, and the stated range covers the measured number.
By their numbers in this assay, from the lowest: compounds 2, 3 and 1 (each within the scatter of the next, the first and the last beyond it).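

Among the compounds shown here, the exchange of benzoyl for phenylsulfonyl on this double-bonded chain carbon gives a 1.6-fold lower number from compound 1 to compound 3 (0.21 log units; within the scatter) in this assay and is the first single-place comparison. At this position, the two groups cannot be told apart in growth inhibition, even though phenylsulfonyl brings an added acceptor by the count. No available measurement bears on the reason for this result.

Still open, on these data alone, is whether a carboxylic acid or a primary amide on this carbon would give a step beyond the scatter. As far as these compounds go, it is also open whether phenylsulfonyl and benzoyl would stay this close on a core carrying a methoxy group.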